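Benzoyl for fluorobenzyl on the piperidine nitrogen: stability outlook

The source may hold more compounds than are shown below. What is called first, only, known or untested is meant among the compounds shown, and "the series" means these compounds.

Measured so far:
compound 1 `Fc1ccc(CN2CCC(NCCSC(c3ccc(F)cc3)c3ccc(F)cc3)CC2)cc1` — 100%
compound 2 `[O-][S+](CCNC1CCN(Cc2ccc(F)cc2)CC1)C(c1ccc(F)cc1)c1ccc(F)cc1` — 100%
compound 3 `[O-][S+](CCNC1CCN(CC(O)Cc2ccccc2)CC1)C(c1ccc(F)cc1)c1ccc(F)cc1` — 100%

In an ADME assay on microsomes from liver (Rattus norvegicus) for metabolic stability, read by LC-MS, using NADPH, tested at 10 uM (on this read-out higher numbers stand for a more stable compound and lower numbers for a less stable compound), compound 1 gives 100% and sits level with compound 2 and compound 3. Going by the values given here, the one measured step on the same nitrogen, no change at the digits printed from compound 2 to compound 3 (within the scatter), left the read-out unchanged. Compound 4 `O=C(c1ccccc1)N1CCC(NCCSC(c2ccc(F)cc2)c2ccc(F)cc2)CC1` differs from compound 1 by benzoyl in place of 4-fluorobenzyl on an amine nitrogen in a ring. Among the compounds with values here, no measured step swaps an amine substituent for an acyl group, so the expectation rests only on the flat run of the three values and on the unchanged step from compound 2 to compound 3. For compound 4 the estimate is 92% (range 65% to 100%), an expected step of a number 8 percentage points lower from compound 1 to compound 4 (within the scatter) that stays within the scatter.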

Compound 4, percent of the compound remaining: 100%
Compound 4: the middle estimate sits 8 percentage points below what was measured; low and high end bracket the measured number.
By their numbers in this assay, from the lowest: compounds 1, 2, 3 and 4 (each within the scatter of the next).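

In this assay, benzoyl in place of 4-fluorobenzyl on the amine nitrogen in a ring reads as no change at the digits printed from compound 1 to compound 4 (within the scatter) and thus extends the flat picture at this position from saturated chain substituents to an acyl group with a carbonyl. The four compounds remain level at the digits printed, so this change does not separate them. No measurement here gives a reason for this result.

Still open, as far as these compounds go, is whether an acetyl or methanesulfonyl group on this nitrogen would stay level with these compounds. From the compounds shown here alone, a carboxylic acid on a longer chain at the same nitrogen is equally open.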